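The source may hold more compounds than are shown below. What is called first, only, known or untested is meant among the compounds shown, and "the series" means these compounds.

Measured in a functional assay on A2780 cells (Homo sapiens) for antiproliferative activity, read by resazurin assay, with a stated time of 72 h; a lower number here means a stronger inhibitor, a higher number a weaker inhibitor:
Compound 1 `NC(=O)c1cc2c(Cc3ccccc3)n[nH]c2cc1O`: "not determined" (no result reported)
Compound 2 `CN(Cc1ccccc1F)C(=O)c1cc2c(Cc3ccccc3)n[nH]c2cc1O`: 1500 nM
Compound 3 `CN(Cc1ccccc1Cl)C(=O)c1cc2c(Cc3ccccc3)n[nH]c2cc1O`: 1100 nM

Compound 3 gives 1100 nM, and compound 2 gives 1500 nM. These two numbers lie within the scatter of each other, and compound 1 offers no number for comparison. The next compound to be tested is compound 4 `CN(Cc1ccc(F)cc1)C(=O)c1cc2c(Cc3ccccc3)n[nH]c2cc1O`. It carries 4-fluorophenyl in place of 2-chlorophenyl on a saturated chain carbon bound to an amide-type nitrogen. Going by the values given here, no measured compound carries the 4-fluorophenyl group, so the evidence is thin. Among the compounds with values here, the one measured step that bears on this change swaps chloro for fluoro on an aromatic carbon. With only a 1.4-fold lower number from compound 2 to compound 3 (0.13 log units; within the scatter) to go on, a step within the scatter, no shift beyond the scatter is expected in this assay. The expected change is a 1.4-fold higher number from compound 3 to compound 4 (0.13 log units; within the scatter). For compound 4 the estimated value is 1500 nM, with an expected range of 700 nM to 3500 nM.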

Compound 4, half-maximal inhibitory concentration: 4100 nM
The estimate for compound 4 lay 2.7-fold (0.44 log units) below the measured number; measured number above the stated range.
By their numbers in this assay, from the lowest: compounds 3 and 2 (each within the scatter of the next); then compound 4.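

In this assay, going by these compounds alone, the change from 2-chlorophenyl to 4-fluorophenyl on a saturated chain carbon bound to an amide-type nitrogen gives a 3.7-fold higher number from compound 3 to compound 4 (0.57 log units; beyond the scatter), the first step at this position that lies beyond the scatter. The comparison with the same halogen gives a 2.7-fold higher number from compound 2 to compound 4 (0.44 log units; beyond the scatter), so 2-fluorophenyl and 4-fluorophenyl are not interchangeable here, although the swap of fluoro for chloro between the two 2-halophenyl compounds stayed within the scatter. Nothing available explains this shift.

The compounds shown leave open whether a phenyl without any halogen, or one carrying a methoxy group or an amine, would read like compound 3 or like compound 4. They also leave open how a longer chain between the amide-type nitrogen and the ring would behave in this assay.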